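The compounds below may be only part of what the source reports. "The series", "measured", "known", "first", "only" and "open" are said of these compounds alone.

Working notes on the sulfonamide series.

Compound 1 `Cc1ccccc1-n1cc(-c2ccccc2NS(=O)(=O)c2c[nH]c(=O)[nH]c2=O)nn1` was tested in a functional assay on SGC-7901 cells (Homo sapiens) for antiproliferative activity, read by MTT assay, with a stated time of 24 h (on this read-out lower numbers stand for stronger inhibition and higher numbers for weaker inhibition), where compound 1 gives 9570 nM. Compound 2 `O=c1[nH]cc(S(=O)(=O)Nc2ccccc2-c2cn(-c3ccccc3F)nn2)c(=O)[nH]1` differs from compound 1 only by fluoro in place of methyl on an aromatic carbon; in this assay compound 2 gives 10800 nM. The step of a 1.1-fold higher number from compound 1 to compound 2 (0.05 log units; within the scatter) is within the scatter, so compound 1 and compound 2 cannot be told apart on these two numbers. Among the compounds with values here, compound 1 has the lower of the two numbers measured so far, with compound 2 sitting within the scatter of it.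

Compound 3 `O=c1[nH]cc(S(=O)(=O)Nc2ccccc2-c2cn(-c3ccc(Cl)cc3)nn2)c(=O)[nH]1` is the next analogue. It differs from compound 1 as follows: 4-chlorophenyl in place of 2-methylphenyl on an aromatic nitrogen

Within the data shown here, the only measured step that bears on this change is the one from compound 1 to compound 2, which exchanges one small substituent for another on the same aryl ring and stays within the scatter. Among the measured compounds shown here, exchanging the whole aryl group for 4-chlorophenyl is a larger change than that, and there is no measured step that tests it directly, so the expectation rests on the single available comparison. On that basis the step of a 1.0-fold higher number from compound 1 to compound 3 (0.02 log units; within the scatter) is expected to be small, with the direction uncertain. For compound 3 in this assay the estimated value is 10000 nM, within a range from 4000 nM to 25000 nM.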

Compound 3, half-maximal inhibitory concentration: 2700 nM
Beside the measured number, compound 3's estimate is 3.7-fold (0.57 log units) above it, and the stated range ends above it.
By their numbers in this assay, from the lowest: compound 3; then compounds 1 and 2 (each within the scatter of the next).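

At this position, on the aromatic nitrogen of the five-membered ring, the aryl group can move the number in this assay beyond the scatter, which the exchange of 2-methylphenyl for 2-fluorophenyl did not show. The 4-chlorophenyl group gives a lower number than either of the groups it replaces (a 3.5-fold lower number from compound 1 to compound 3 (0.55 log units; beyond the scatter)) and (a 4.0-fold lower number from compound 2 to compound 3 (0.60 log units; beyond the scatter)), and the two steps agree in direction and are both modest in size. Nothing among the data accounts for this gain, which therefore stands as an observation on three compounds only.

The change from compound 1 or compound 2 to compound 3 alters both the substituent on the phenyl ring and its location on that ring, so these compounds cannot show whether the chlorine itself or its location carries the step. That question, and whether the lower number extends to other groups at this position, would turn on how 2-chlorophenyl, 4-fluorophenyl, 4-methylphenyl and unsubstituted phenyl stand beside compound 3 in this assay on the same core.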